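Ethoxy in Place of Benzyl: Two Weak Antiproliferative Compounds

The compounds below may be only part of what the source reports. "The series", "measured", "known", "first", "only" and "open" are said of these compounds alone.

compound 1 `O=C1OCC[C@@H]1NC(=S)SCCOc1ccccc1Cc1ccccc1` 32300 nM
compound 2 `O=C(CNc1ccc(Cl)cc1Cl)N[C@H]1CCOC1=O` > 64000 nM

In a functional assay on MGC-803 cells (Homo sapiens) for antiproliferative activity, read by MTT assay, with a stated time of 72 h (a higher number here means a weaker inhibitor, a lower number a stronger inhibitor), compound 1 gives 32300 nM, the only number shown among the two measured compounds. Compound 2 is a different case: its value of > 64000 nM is a limit of the assay, not a number. Compound 1 therefore stands alone as a measured figure, with the other result sitting at the limit of > 64000 nM in this assay, at which 1 of the 2 values shown sits.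

Compound 3 `CCOc1ccccc1OCCSC(=S)N[C@H]1CCOC1=O` differs from compound 1 in one place: ethoxy in place of benzyl on an aromatic carbon. Among the measured compounds shown here, no pair of measured compounds separated by this change is available, so the size of the step cannot be read from the data. Given that compound 1 already sits at 32300 nM, the step of a 1.4-fold higher number from compound 1 to compound 3 (0.14 log units; within the scatter) is expected to be small, either none beyond the scatter or a slight move toward a weaker inhibitor. Compound 3 is accordingly estimated at 45000 nM, within a range from 15000 nM to 120000 nM.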

Compound 3, half-maximal inhibitory concentration: > 64000 nM
Compound 3: a limit, no number (the forecaster's own chance of this, stated with the estimate: 35%); middle value at least 1.4-fold (0.15 log units) away from the limit.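

The change of benzyl to ethoxy, on an aromatic carbon ortho to a large group, gives an at least 1.9-fold higher number from compound 1 to compound 3 (0.29 log units; that floor lies within the scatter). The result for compound 3 is a limit and not a number, so this step is only a floor, and it cannot show that the change weakens compound 1 beyond the usual scatter. What the position does now show is that ethoxy here gives no measured number in this assay, and compound 3 joins compound 2 at the limit: the limit of > 64000 nM in this assay, at which 2 of the 3 values shown sit.

From the compounds shown here alone, how far compound 3 lies past its limit stays open, and with it the true size of the step. Also open, going by these compounds, is how a methoxy group, a hydroxyl group, an amine or a longer alkoxy chain at this position would compare with benzyl.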